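Swapping Chloro for Fluoro on a Core Seen Only at the Limit

This account rests on a few compounds, and the source may have more. Where it says the series, first, only, none or still open, it means among the compounds named here.

Three compounds share one core, and all three are known only as limits. Compound 1 is `Cc1ccc(C(=O)NC2CCCCCC2)c(=O)n1Cc1ccc(F)cc1`; in an assay on HEK293 cells for inhibition of Monoacylglycerol lipase ABHD6 (Homo sapiens), read by scintillation counting, with stated times of 30 min and 5 min (on this read-out lower numbers stand for stronger inhibition and higher numbers for weaker inhibition), compound 1 gives a limit, > 10000 nM. Compound 2 is `Cc1c(Br)cc(C(=O)NC2CCCCCC2)c(=O)n1Cc1ccc(F)cc1`; in this assay compound 2 also gives a limit, > 10000 nM. Compound 3 is `Cc1c(Cl)cc(C(=O)NC2CCCCCC2)c(=O)n1Cc1ccc(F)cc1`; in this assay compound 3 likewise gives a limit, > 10000 nM. So compound 3 stands where the other two stand, at the boundary of what the assay reports, a situation summed up by the fact that (the limit of > 10000 nM in this assay, at which 3 of the 3 values shown sit). The steps a step that the two limits leave unreadable from compound 1 to compound 2, a step that the two limits leave unreadable from compound 1 to compound 3 and a step that the two limits leave unreadable from compound 2 to compound 3 therefore cannot be sized at all.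

Compound 4 is `Cc1c(F)cc(C(=O)NC2CCCCCC2)c(=O)n1Cc1ccc(F)cc1`. The change is fluoro in place of chloro on an aromatic carbon. The steps between compound 1, compound 2 and compound 3 are all unreadable from the limit. Going by the values given here, no measured step gives a direction. A small halogen swap on a core whose known members are all at the limit is expected to leave compound 4 there as well, with an estimated step that the limit leaves unreadable from compound 3 to compound 4. Compound 4 is expected to give about 20000 nM, within a range from 7000 nM to 80000 nM.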

Compound 4, half-maximal inhibitory concentration: > 10000 nM
Compound 4 ended at the assay's limit; the forecaster's own chance of this, stated with the estimate: 85%; the middle value does not contradict the limit.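

Going by these compounds alone, no step to compound 4 from compound 1, compound 2 or compound 3 can be read, because all four values are limits and not numbers: the limit of > 10000 nM in this assay, at which 4 of the 4 values shown sit. On these data alone, what stays open is how strongly each compound inhibits in this assay, and whether hydrogen, bromo, chloro and fluoro differ at all at this place.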